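The compounds below may be only part of what the source reports. "The series", "measured", "known", "first", "only" and "open" are said of these compounds alone.

Measured so far in an assay (Cricetulus griseus) for inhibition of Monoamine oxidase (Homo sapiens); a higher number here means a weaker inhibitor, a lower number a stronger inhibitor:
compound 1, `NCCCCCCOc1ccc2c(=O)c(-c3ccc(O)cc3)coc2c1` — compound 1 gives >> 9000 nM, a limit of the assay rather than a number.
compound 2, `CCCCCCC(Oc1ccc2c(=O)c(-c3ccc(O)cc3)coc2c1)C(=O)OCC` — compound 2 gives >> 9000 nM, likewise a limit rather than a number.

Compound 1 stands at the limit of >> 9000 nM in this assay, at which 2 of the 2 values shown sit. For the measured compounds named here, since neither value shown is a number, compound 1 and compound 2 cannot be ordered against each other, and no step between measured compounds is available to calibrate the series.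

Compound 3, `CC(C)Oc1ccc2c(=O)c(-c3ccc(O)cc3)coc2c1`, differs from compound 1 by isopropyl in place of 6-aminohexyl on an oxygen on an aromatic ring. With the measured values sitting only as limits, the step is not anchored in either direction; the expectation is that the change from compound 1 to compound 3 amounts to an at least 1.5-fold lower number from compound 1 to compound 3 (0.17 log units; that floor lies within the scatter), a shift that could be modest in the direction of a stronger inhibitor but need not go beyond the scatter. Compound 3 is therefore estimated at 6000 nM in this assay, with a range from 1000 nM to 30000 nM, and a fair chance that the result is again reported only as a limit.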

Compound 3, half-maximal inhibitory concentration: 200 nM
Compound 3: middle estimate off by 30-fold (1.48 log units), on the high side; the measured number lies below the stated range.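

In this assay, for the compounds shown here, compound 3 gives 200 nM, the first actual number, which shows that a substituent on this oxygen on an aromatic ring can leave measurable inhibition on the shared core. Replacing 6-aminohexyl with isopropyl gives an at least 45-fold lower number from compound 1 to compound 3 (1.65 log units; beyond the scatter), and this is only a floor, as the value of compound 1 is a limit of the assay and not a number. The series is therefore no longer uniform, although most of its values still stand at the limit: the limit of >> 9000 nM in this assay, at which 2 of the 3 values shown sit.

The step changes chain size and removes the amine together, so the compounds shown do not assign it to either change. A plain hexyl chain or an unbranched propyl on the same oxygen would separate these two changes and test whether the branching of isopropyl matters.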